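Removing one hydroxy from compound 3

A few compounds are considered here, and "the series" means these few. Any claim that something is new, unique, unknown or untested is made for them only; others in the source may bear on it.

Measured in a functional assay on Bel-7402 cells (Homo sapiens) for antiproliferative activity, read by MTT assay, with a stated time of 72 h; on this read-out higher numbers stand for weaker inhibition and lower numbers for stronger inhibition:
Compound 1 `COc1ccc(Cn2c(C(=O)O)c(CNCc3cccc(OC)c3)c3ccccc32)cc1`: 52900 nM
Compound 2 `COc1ccc(Cn2c(C(=O)O)c(CN(C)Cc3cccc(OC)c3)c3ccc(C)cc32)cc1`: 33000 nM
Compound 3 `COc1ccc(Cn2c(C(=O)O)c(CNCc3cc(OC)ccc3O)c3ccc(C)cc32)cc1`: > 50000 nM, a limit and not a number

Compound 3 has no number of its own and stands only at the limit of > 50000 nM in this assay, at which 1 of the 3 values shown sits. Compound 4 `COc1ccc(Cn2c(C(=O)O)c(CNCc3cccc(OC)c3)c3ccc(C)cc32)cc1`, not yet measured, carries hydrogen in place of hydroxy on an aromatic carbon, so that (2-hydroxy-5-methoxybenzyl)amino becomes (3-methoxybenzyl)amino.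

For the measured compounds named here, one measured step bears directly on this change: an at least 1.5-fold higher number from compound 2 to compound 3 (0.18 log units; that floor lies within the scatter). That step also replaces (3-methoxybenzyl)(methyl)amino, so it does not isolate the hydroxy, and it gives only a floor. The better guide is the pair of compounds that already carry the 3-methoxybenzyl group: compound 1 at 52900 nM and compound 2 at 33000 nM. These two values lie within the usual scatter of each other.

In this assay a somewhat lower number is therefore expected, but no change clearly beyond the scatter. The estimated size of the change is an at least 1.2-fold lower number from compound 3 to compound 4 (0.09 log units; that floor lies within the scatter). For compound 4 the expected value is 40000 nM, with an estimated range from 18000 nM to 80000 nM.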

Compound 4, half-maximal inhibitory concentration: 9830 nM
Estimate against measurement, compound 4: 4.1-fold (0.61 log units) above, and the stated range ends above it.
By their numbers in this assay, from the lowest: compound 4; then compounds 2 and 1 (each within the scatter of the next).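

In this assay, replacing the hydroxy with hydrogen, so that (2-hydroxy-5-methoxybenzyl)amino becomes (3-methoxybenzyl)amino, gives an at least 5.0-fold lower number from compound 3 to compound 4 (0.70 log units; beyond the scatter). This is the first step shown that isolates the hydroxy, and unlike the earlier floor it lies beyond the scatter. Compound 3 has only a limit and not a number, so the size of this step is a floor: the limit of > 50000 nM in this assay, at which 1 of the 4 values shown sits. Compound 4 also shows that two other single changes count on this scaffold: hydrogen in place of methyl on the amine nitrogen gives a 3.4-fold lower number from compound 2 to compound 4 (0.53 log units; beyond the scatter), and methyl in place of hydrogen on an aromatic carbon of the core gives a 5.4-fold lower number from compound 1 to compound 4 (0.73 log units; beyond the scatter).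

The compounds shown leave open whether a methoxy group or a fluorine at the place of the hydroxy would behave like hydrogen or like the hydroxy. They also leave open whether the carboxylic acid on the core could give way to an ester or an amide without losing the stronger inhibition seen with compound 4.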